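A few compounds are considered here, and "the series" means these few. Any claim that something is new, unique, unknown or untested is made for them only; others in the source may bear on it.

Of the compounds shown here, three have been measured in a functional assay on K562 cells (Homo sapiens) for inhibition, read by trypan blue exclusion, with a stated time of 72 h; a higher number here means a weaker inhibitor, a lower number a stronger inhibitor. Compound 1 `CCCn1c(=O)c(S(=O)(=O)c2ccc(F)cc2F)cc2cnc(Nc3ccc4[nH]ccc4c3)nc21` carries a propyl group on its core and gives 1000 nM in this assay, the lowest of the three numbers. Compound 2 `COC(=O)Cn1ccc2cc(Nc3ncc4cc(S(=O)(=O)c5ccc(F)cc5F)c(=O)n(C)c4n3)ccc21` gives 5000 nM, and compound 3 `Cc1ccc(S(=O)(=O)c2cc3cnc(Nc4cnc5c(c4)CC(=O)N5)nc3n(C)c2=O)cc1` gives 15000 nM; both of these gaps to compound 1 lie beyond the usual scatter of repeated measurements, so compound 1 is the strongest inhibitor of the three in this assay. Compound 2 and compound 3 differ from compound 1 in several places at once, so nothing can be said about any single part of them.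

Compound 4 `CCn1c(=O)c(S(=O)(=O)c2ccc(F)cc2F)cc2cnc(Nc3ccc4[nH]ccc4c3)nc21` has not yet been measured. It differs from compound 1 in one place only, (hydrogen in place of methyl on a saturated chain carbon, two bonds along the chain from an aromatic nitrogen), which reads as propyl to ethyl. Among the measured compounds shown here, no measured pair shows a change of this kind, so there is no direct guide. A loss of a single carbon on a saturated chain is usually a modest step, and with no evidence pointing either way the expectation is a step of no more than the usual scatter, in either direction.

Compound 4 is therefore expected to give about 1200 nM in this assay, within a range from 500 nM to 3000 nM. The expected step of a 1.2-fold higher number from compound 1 to compound 4 (0.08 log units; within the scatter) is estimated to stay within the scatter.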

Compound 4, half-maximal inhibitory concentration: 750 nM
Compound 4: middle estimate off by 1.6-fold (0.20 log units), on the high side, and the stated range covers the measured number.
By their numbers in this assay, from the lowest: compounds 4 and 1 (each within the scatter of the next); then compound 2; then compound 3.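

In this assay, replacing propyl with ethyl on the core of compound 1 gives a 1.3-fold lower number from compound 1 to compound 4 (0.12 log units; within the scatter). This is the first change in one place only among the compounds shown, and it reveals that removing this methyl, on a saturated chain carbon two bonds along the chain from an aromatic nitrogen, leaves a difference no larger than repeat measurements of one compound would usually show, so propyl and ethyl cannot be told apart here. Nothing measured alongside these compounds offers an explanation for this result.

Among the compounds shown here, the single step covers only the move from propyl to ethyl, so how a longer chain such as butyl, or a chain ending in an amine or a carboxylic acid, would read at this place remains open. From the compounds shown here alone, compound 2 and compound 3 differ from compound 1 in several places at once, so it also remains open whether the same change would read alike when the other parts of the molecule are different.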